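Cytotoxicity Limits and a Carbamoyl for Methyl Swap

The source may report more compounds than this note shows. Statements on the series, on what has been measured and on what is new or still open speak of the compounds shown alone.

Compound 1, `Cc1cc(NC(=O)Nc2ccc(C)c(Cl)c2)c2ccccc2n1`, gives in an ADME assay on HepG2 cells (Homo sapiens) for cytotoxicity, with a stated time of 72 h (a lower number here means that less compound is needed, a higher number that more compound is needed for the effect), a limit of the assay, > 25000 nM.
Compound 2, `Cc1ccc(NC(=O)Nc2cc(C)nc3ccccc23)cc1`, gives the limit > 25000 nM.
Compound 3, `Cc1cc(NC(=O)Nc2ccccc2F)c2ccccc2n1`, gives the limit > 25000 nM.

Compound 2 thus stands at the same limit as the other two measured compounds, as recorded by the limit of > 25000 nM in this assay, at which 3 of the 3 values shown sit. Compound 4, `Cc1cc(NC(=O)Nc2ccc(C(N)=O)cc2)c2ccccc2n1`, differs from compound 2 by carbamoyl in place of methyl on an aromatic carbon. Among the compounds with values here, the steps that bear on this change are a step that the two limits leave unreadable from compound 1 to compound 2 and a step that the two limits leave unreadable from compound 2 to compound 3; neither has a readable size, so neither a direction nor a size beyond the scatter can be drawn from them. Compound 4 is therefore expected to remain at the limit, with an estimated 50000 nM and a range from 20000 nM to 150000 nM. The expected step is accordingly a step that the limit leaves unreadable from compound 2 to compound 4.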

Compound 4, half-maximal effective concentration: > 25000 nM
Compound 4 gave a limit, no number; the forecaster's own chance of this, stated with the estimate: 85%; the middle value lies beyond the limit too.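

Compound 2 and compound 4 each give only a limit of the assay, not a number, so no step between them can be read: the limit of > 25000 nM in this assay, at which 4 of the 4 values shown sit.

The compounds shown leave open where any of them would reach half-maximal effect in this assay, and whether carbamoyl in place of methyl shifts it.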